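Swapping the amide for an ethyl amine on the spiro ring

The source may hold more compounds than are shown below. What is called first, only, known or untested is meant among the compounds shown, and "the series" means these compounds.

Compound 1 `CCC(=O)N1CC2(CC(NC(=O)c3cc(-c4ccccc4)no3)C2)C1`: 68%
Compound 2 `CN(C)C(=O)CCNC(=O)c1cc(C2CCCCC2)no1`: > 100%

For the measured compounds named here, in an ADME assay on microsomes from liver (Homo sapiens) for metabolic stability, with a stated time of 0.5 h, tested at 0.5 mg/mL (on this read-out lower numbers stand for a less stable compound and higher numbers for a more stable compound), compound 1 gives 68%, the only plain number in the set. Compound 2 reaches only a limit of the assay, > 100%, as the limit of > 100% in this assay, at which 1 of the 2 values shown sits, shows. Compound 3 `CCN1CC2(CC(NC(=O)c3cc(-c4ccccc4)no3)C2)C1` is not yet measured; it differs from compound 1 by ethyl in place of propanoyl on an amine nitrogen in a ring. Going by the values given here, no measured pair tells how such a change plays out here, so a modest drop is expected from compound 1 to compound 3 , a number 18 percentage points lower from compound 1 to compound 3 (beyond the scatter), beyond the scatter. Compound 3 is expected to give about 50%, from 25% to 80%.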

Compound 3, percent of the compound remaining: 100%
Beside the measured number, compound 3's estimate is 50 percentage points below it; the whole stated range lies below it.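

In this assay, for the compounds shown here, the amine nitrogen in a ring proves to be a position that matters, which no earlier pair could show: ethyl in place of propanoyl gives a number 32 percentage points higher from compound 1 to compound 3 (beyond the scatter). The core of compound 1 therefore does not hold the read-out down on its own, and the propanoyl group is not needed for a high value. Compound 3 stands near the top of the read-out, so any further gain would be hard to size: the limit of > 100% in this assay, at which 1 of the 3 values shown sits.

The compounds shown leave open whether the step follows the loss of the carbonyl or the shorter chain. An acetyl, a propyl or a methyl group on the same nitrogen would bear on that question.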